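The source may report more compounds than this note shows. Statements on the series, on what has been measured and on what is new or still open speak of the compounds shown alone.

Measured so far in a functional assay on SW-620 cells (Homo sapiens) for inhibition, read by sulforhodamine B assay, with a stated time of 48 h; on this read-out lower numbers stand for stronger inhibition of growth and higher numbers for weaker inhibition of growth:
- compound 1 `N#C/C(=C\N1CCN(C(=O)c2ccco2)C1=S)C(N)=O`: 22100 nM
- compound 2 `O=CN1CCN(c2ccc(Cl)c(Cl)c2)C1=S`: 19400 nM
- compound 3 `O=CN1CCN(c2cc(Cl)cc(Cl)c2)C1=S`: 19000 nM

Compound 1 carries the highest of the three numbers, yet its gaps to compound 2 and to compound 3 both lie within the scatter, so the three stand at one level of weak growth inhibition and no order among them can be read. Within the data shown here, no pair of measured compounds differs in a single place, so the series offers no measured step to lean on.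

Compound 4 `N#C/C(=C\N1CCN(C(=O)c2ccco2)C1=S)C(=O)c1ccccc1` is compound 1 with phenyl in place of amino on a carbonyl carbon; cut one bond further out, the change reads carbamoyl to benzoyl. Among the measured compounds shown here, nothing among the measured compounds shows what this exchange does. For the measured compounds named here, with no comparable step known, the expectation in this assay is a step of modest size at most, with no clear direction, and quite possibly none beyond the scatter. The estimated step from compound 1 to compound 4 is a 1.4-fold lower number from compound 1 to compound 4 (0.14 log units; within the scatter). Compound 4 is therefore expected to give 16000 nM in this assay, with a range from 5000 nM to 50000 nM.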

Compound 4, concentration for 50% growth inhibition: 5900 nM
Compound 4: middle estimate off by 2.7-fold (0.43 log units), on the high side; the range from low to high includes it.
By their numbers in this assay, from the lowest: compound 4; then compounds 3, 2 and 1 (each within the scatter of the next).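

Among these compounds, the carbonyl carbon that carries the amino group in compound 1 is a place where the series responds in this assay: phenyl in place of amino gives a 3.7-fold lower number from compound 1 to compound 4 (0.57 log units; beyond the scatter), the first measured single-place step and a modest one. The amino group is therefore not needed for growth inhibition on this read-out, and a six-membered aromatic ring of carbon only is accepted on that carbon with a gain in inhibition. Nothing at hand accounts for this gain.

On these data alone, since this one exchange removes the amino group and adds the phenyl together, it remains open whether the loss of one or the arrival of the other carries the step. Methyl, dimethylamino or chlorophenyl on the same carbonyl carbon would help to separate these two readings.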